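This account rests on a few compounds, and the source may have more. Where it says the series, first, only, none or still open, it means among the compounds named here.

In a functional assay on SNB-75 cells (Homo sapiens) for inhibition, read by sulforhodamine B assay, with a stated time of 48 h, tested at 10 uM (a lower number here means a stronger effect, a higher number a weaker effect of the compound at the concentration tested), the measured compounds are: compound 1 `COc1cc(Cl)cc(-c2nn(-c3cccc(NC(=O)Nc4cccc(C(F)(F)F)c4)c3)cc2-c2ccncc2)c1` with 12.5%; compound 2 `COc1cc(Cl)cc(-c2nn(-c3cccc(NC(=O)c4cc(C(F)(F)F)cc(C(F)(F)F)c4)c3)cc2-c2ccncc2)c1` with 60.8%; compound 3 `COc1cc(Cl)cc(-c2nn(-c3cccc(NC(=O)c4ccc(Cl)c(Cl)c4)c3)cc2-c2ccncc2)c1` with 50.6%.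

Compound 3 stands second highest of the three numbers; nearest is compound 2, higher by a margin beyond the scatter, and furthest is compound 1, lower by a margin beyond the scatter. Compound 4 `COc1cc(Cl)cc(-c2nn(-c3cccc(NC(=O)c4cccc(C(F)(F)F)c4)c3)cc2-c2ccncc2)c1` differs from compound 3 by 3-(trifluoromethyl)phenyl in place of 3,4-dichlorophenyl on a carbonyl carbon. Among the measured compounds shown here, the only measured step, a number 38.1 percentage points higher from compound 1 to compound 3 (beyond the scatter), also exchanges a urea for an amide, so it bears on this change only loosely. The two amides, compound 2 and compound 3, lie fairly close to each other. A step within or near the scatter is therefore expected, estimated as a number 4.4 percentage points higher from compound 3 to compound 4 (within the scatter). For compound 4 the value is estimated at 55%, range 35% to 75%.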

Compound 4, a percentage reported as activity, at one concentration (the size of the read-out at that concentration, not a potency): 53.9%
Compound 4: middle estimate off by 1.1 percentage points, on the high side; measured number inside the range.
By their numbers in this assay, from the lowest: compound 1; then compounds 3, 4 and 2 (each within the scatter of the next, the first and the last beyond it).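

In this assay, 3-(trifluoromethyl)phenyl in place of 3,4-dichlorophenyl on the carbonyl carbon gives a number 3.3 percentage points higher from compound 3 to compound 4 (within the scatter) and loss of one trifluoromethyl gives a number 6.9 percentage points lower from compound 2 to compound 4 (within the scatter), so compound 4 is not separated from either amide. With the same aryl group on both sides, the urea-to-amide change alone gives a number 41.4 percentage points higher from compound 1 to compound 4 (beyond the scatter), which ties the large difference to the amino nitrogen on the carbonyl carbon rather than to the aryl group. No measurement on hand gives a cause for this difference.

Open, as far as these compounds go, is whether a urea carrying 3,4-dichlorophenyl matches compound 1. Also open, from the compounds shown here alone, is how an amine or a carboxylic acid in place of trifluoromethyl would read in the urea.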